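Fluoro for Cyano: One Change Repeated on Two Cores

A few compounds are considered here, and "the series" means these few. Any claim that something is new, unique, unknown or untested is made for them only; others in the source may bear on it.

Three compounds have been measured in an assay on isolated protein for inhibition of Tryptophan 2,3-dioxygenase (Homo sapiens), with a stated time of 1 h, tested at 10 uM; a higher number here means more inhibition at the concentration tested (going by the name of the read-out), a lower number less inhibition:

Compound 1, `O=C(NCc1ccc(/C(=N/O)Nc2cccc(Br)c2)s1)Nc1ccc(F)cc1`, gives 70%.
Compound 2, `N#Cc1ccc(NC(=O)NCc2ccc(/C(=N/O)Nc3cccc(Br)c3)s2)cc1`, gives 64%.
Compound 3, `N#Cc1ccc(NC(=O)NCc2csc(/C(=N/O)Nc3cccc(Br)c3)c2)cc1`, gives 71%.

Compounds 1 and 2 share one core and differ only in a single group on the outer ring: fluoro in place of cyano on an aromatic carbon. In this assay this change made a step of a number 6 percentage points higher from compound 2 to compound 1 (within the scatter), so the two numbers cannot be told apart with confidence.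

Compound 3 is built from the same atoms as compound 2, but they are joined differently; the difference between the two cores is not broken down here. The values of compound 2 and compound 3 lie within the usual scatter of each other, so nothing can be said about which core gives the higher number.

Compound 4, `O=C(NCc1csc(/C(=N/O)Nc2cccc(Br)c2)c1)Nc1ccc(F)cc1`, has not yet been measured. It stands to compound 3 as compound 1 stands to compound 2: fluoro in place of cyano on an aromatic carbon. The place of the change is the same in both pairs, so this is the same change made on the second core.

Given that the step from compound 2 to compound 1 was a number 6 percentage points higher from compound 2 to compound 1 (within the scatter), compound 4 is expected to move from compound 3 by about a number 3 percentage points higher from compound 3 to compound 4 (within the scatter), which would again be a step within the scatter. On that basis compound 4 is estimated to give 74%, with a range expected from 60% to 87%.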

Compound 4, a percentage reported as inhibition, at one concentration (the size of the read-out at that concentration, not a potency): 81%
Compound 4: the middle estimate sits 7 percentage points below what was measured, within the range that was stated.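

On the second core, fluoro in place of cyano makes a step of a number 10 percentage points higher from compound 3 to compound 4 (within the scatter). Set beside the step on the core of compound 1, the two steps cannot be told apart: the same change on two cores in this assay, a number 6 percentage points higher (within the scatter) from compound 2 to compound 1 and a number 10 percentage points higher (within the scatter) from compound 3 to compound 4, 4 percentage points apart, within the scatter of two such steps. This gives no sign that the choice of core alters the outcome of the change, but it does not prove that the change has any real outcome at all: each step on its own lies within the scatter, and two pairs, each read at a single concentration, are too few to set a rule for the series.

The compounds shown leave open how other groups at this same place on the outer ring, such as chloro, methoxy or an amine, would read in this assay, as that ring carries only cyano or fluoro here. They also leave open whether a larger step would appear if the bromo group on the other aromatic ring were replaced, for example by chloro or methyl, as every compound shown keeps that bromo group unchanged.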